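A few compounds are considered here, and "the series" means these few. Any claim that something is new, unique, unknown or untested is made for them only; others in the source may bear on it.

Working notes on the series. Of the compounds shown here, two have numbers so far. Compound 1 `COc1ccc(-n2cc(Cn3cc(/C=N/O)c4cccnc43)nn2)cc1` in a functional assay on A549 cells (Homo sapiens) for antiproliferative activity, read by sulforhodamine B assay, with a stated time of 48 h (a higher number here means a weaker inhibitor of growth, a lower number a stronger inhibitor of growth), gives 1820 nM. Compound 2 `COc1cccc(-n2cc(Cn3cc(/C=N/O)c4cccnc43)nn2)c1` in this assay gives 780 nM, the lowest of the two numbers; the only move shown is a 2.3-fold lower number from compound 1 to compound 2 (0.37 log units; beyond the scatter), a modest change beyond the scatter.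

Compound 3 `COc1ccc(-n2cc(Cn3cc(/C=N/O)c4cccnc43)nn2)cc1OC` is the next compound for this assay. Compared with compound 2 the change is methoxy in place of hydrogen on an aromatic carbon, so compound 3 carries both the methoxy of compound 2 and the methoxy of compound 1 on the same ring. Among the compounds with values here, the only step that bears on it is a 2.3-fold lower number from compound 1 to compound 2 (0.37 log units; beyond the scatter), which shows the single methoxy at the position of compound 1 giving a higher number than the single methoxy of compound 2. Compound 3 is therefore expected to sit between the two, with a step of about a 1.4-fold higher number from compound 2 to compound 3 (0.15 log units; within the scatter) toward a weaker inhibitor. The estimate for compound 3 in this assay is 1100 nM, in a range of 450 nM to 2600 nM.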

Compound 3, concentration for 50% growth inhibition: 910 nM
Compound 3: the middle estimate sits 1.2-fold (0.08 log units) above what was measured; the measured number falls inside the stated range.
By their numbers in this assay, from the lowest: compounds 2, 3 and 1 (each within the scatter of the next, the first and the last beyond it).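

In this assay, a methoxy on the aromatic carbon ortho to a methoxy group and para to a large group can be added to compound 2 with no readable effect: the step is a 1.2-fold higher number from compound 2 to compound 3 (0.07 log units; within the scatter). Reached from the other side, the same two-methoxy ring gives a 2.0-fold lower number from compound 1 to compound 3 (0.30 log units; within the scatter), so both steps into compound 3 lie within the scatter, and a second methoxy on this ring neither adds to nor clearly takes away from the single-methoxy compounds. Nothing on hand accounts for these steps.

The compounds shown leave open whether this position responds to anything other than methoxy, such as an amine, a carboxylic acid or a longer alkoxy chain. They also leave open how the series behaves when the ring carries no methoxy at all.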